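Anilino series: removing the methoxy group

A few compounds are considered here, and "the series" means these few. Any claim that something is new, unique, unknown or untested is made for them only; others in the source may bear on it.

Measured so far:
compound 1 `O=C1C=C(Nc2ccc(I)cc2)C(=O)c2c1nc1n2[C@H]2OC[C@@H](O)[C@H]2OC1` gives 2300 nM
compound 2 `COc1cccc(NC2=CC(=O)c3c(nc4n3[C@H]3OC[C@@H](O)[C@H]3OC4)C2=O)c1` gives 3340 nM

In a functional assay on ECa-109 cells for inhibition, with ECa-109 cell line (Homo sapiens) as the target, read by sulforhodamine B assay (a higher number here means a weaker inhibitor, a lower number a stronger inhibitor), compound 2 stands at one end of the two numbers shown, separated from compound 1 by a gap that lies within the scatter, so neither is read as apart from the other. Compound 3 `O=C1C(Nc2ccccc2)=CC(=O)c2c1nc1n2[C@H]2OC[C@@H](O)[C@H]2OC1` is not yet measured; the difference from compound 2 is hydrogen in place of methoxy on an aromatic carbon. Among the measured compounds shown here, no step between measured compounds is available to calibrate this change, so no move beyond the scatter is expected in this assay. The estimated step of a 1.1-fold lower number from compound 2 to compound 3 (0.05 log units; within the scatter) is small, and compound 3 is expected at 3000 nM, ranging from 1200 nM to 8000 nM.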

Compound 3, half-maximal inhibitory concentration: 3560 nM
Compound 3: the middle estimate sits 1.2-fold (0.07 log units) below what was measured; the range from low to high includes it.
By their numbers in this assay, from the lowest: compounds 1, 2 and 3 (each within the scatter of the next).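

In this assay, among the compounds shown here, hydrogen in place of methoxy on an aromatic carbon gives a 1.1-fold higher number from compound 2 to compound 3 (0.03 log units; within the scatter) and provides the first calibration of this change in the anilino series. At this position, meta to a large group, the 3-methoxyphenyl and phenyl compounds therefore cannot be told apart, and the methoxy group is not required to retain the activity of compound 2. Nothing on hand explains this result. From the compounds shown here alone, whether an amine or a carboxylic acid on this carbon would move the number beyond the scatter remains open. The same question stands for a longer alkoxy chain.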